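The source may report more compounds than this note shows. Statements on the series, on what has been measured and on what is new or still open speak of the compounds shown alone.

compound 1 `CNC(=O)Nc1ccc(-c2nc(N3CC4CCC(C3)O4)c3cnn(C)c3n2)cc1` gives 170 nM
compound 2 `CNC(=O)Nc1ccc(-c2nc(N3CC4CCC(C3)O4)c3cnn(CCO)c3n2)cc1` gives 650 nM

Both values come from a functional assay on LNCaP cells (Homo sapiens) for cytotoxicity (on this read-out lower numbers stand for stronger inhibition and higher numbers for weaker inhibition), and compound 2, at 650 nM for the second time of telling, holds the higher of the two numbers, which makes it the weaker of the pair. Compound 3 `CNC(=O)Nc1ccc(-c2nc(N3CC4CCC(C3)O4)c3cnn([C@H]4CC[C@@H](O)CC4)c3n2)cc1` has not been measured yet. It differs from compound 2 on an aromatic nitrogen, where 4-hydroxycyclohexyl stands in place of 2-hydroxyethyl (4-hydroxycyclohexyl in place of 2-hydroxyethyl on an aromatic nitrogen). For the measured compounds named here, only one measured step concerns this same nitrogen (a 3.8-fold higher number from compound 1 to compound 2 (0.58 log units; beyond the scatter)) and it is modest, though beyond the scatter. That step shows that changing the group here can move the number, but it involved no ring, so it says little about what a six-membered ring will do. Both the leaving and the entering group carry a hydroxy, so only a small change is expected in this assay with a slight lean towards a lower number, probably within the scatter. The expected step is small (a 1.4-fold lower number from compound 2 to compound 3 (0.13 log units; within the scatter)) and remains an estimate. The estimate for compound 3 is 480 nM with 150 nM to 1500 nM as the expected range.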

Compound 3, half-maximal inhibitory concentration: 20 nM
For compound 3 the middle estimate is 24-fold (1.38 log units) above the measured one; the whole stated range lies above it.
By their numbers in this assay, from the lowest: compound 3; then compound 1; then compound 2.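

In this assay the group on this aromatic nitrogen proves able to move the number much further than the earlier step showed: 4-hydroxycyclohexyl in place of 2-hydroxyethyl gives a 33-fold lower number from compound 2 to compound 3 (1.51 log units; beyond the scatter) in a large step, even though both groups carry a hydroxy. A hydroxy on the group is therefore not enough to set the number here, and the same ring group also compares well with plain methyl, giving an 8.5-fold lower number from compound 1 to compound 3 (0.93 log units; beyond the scatter) in a modest step that is still beyond the scatter. The two groups with a hydroxy thus fall on opposite sides of methyl, with compound 2 above compound 1 and compound 3 below it, and no measurement at hand accounts for this difference.

The compounds shown leave open whether the six-membered ring alone carries this gain or whether it needs the hydroxy on it, a question that plain cyclohexyl would address. They also leave open how much depends on the defined stereocentres of the ring, and whether an amine in place of the hydroxy, as in 4-aminocyclohexyl, would keep the low number.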